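Chloro to difluoromethyl on a shared core

The source may report more compounds than this note shows. Statements on the series, on what has been measured and on what is new or still open speak of the compounds shown alone.

Compound 1 `CC(=O)NCc1cccc(Cn2nc(NS(=O)(=O)c3ccc(Cl)s3)c3c(Cl)cccc32)c1` gives 6.03 in a physicochemical assay for acid dissociation
Compound 2 `CC(=O)NCc1cccc(Cn2nc(NS(=O)(=O)c3ccc(Cl)s3)c3c(C(C)O)cccc32)c1` gives 5.62 in this assay
Compound 3 `CC(=O)NCc1cccc(Cn2nc(NS(=O)(=O)c3ccc(Cl)s3)c3c(C(C)(C)O)cccc32)c1` gives 5.46 in this assay

Compound 1 stands highest of these three, and both others lie beyond the scatter from it. Compound 4 `CC(=O)NCc1cccc(Cn2nc(NS(=O)(=O)c3ccc(Cl)s3)c3c(C(F)F)cccc32)c1` has difluoromethyl in place of chloro on an aromatic carbon and is not yet measured. Two measured steps replace that same chloro: a number 0.41 log units lower from compound 1 to compound 2 (beyond the scatter) and a number 0.57 log units lower from compound 1 to compound 3 (beyond the scatter) are both modest. The third step, a number 0.16 log units lower from compound 2 to compound 3 (within the scatter), stays within the scatter. Neither modest step involves difluoromethyl, so they serve only as a rough guide. A somewhat smaller step in the same direction is expected in this assay, estimated as a number 0.33 log units lower from compound 1 to compound 4 (beyond the scatter) on that basis. Compound 4 is expected at 5.7 (estimated range 5.35 to 6.05).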

Compound 4, acid dissociation constant: 5.6
Compound 4: the middle estimate sits 0.10 log units above what was measured; the range from low to high includes it.
By their numbers in this assay, from the lowest: compounds 3, 4 and 2 (each within the scatter of the next); then compound 1.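

In this assay, this third replacement of the chloro on the aromatic carbon gives a number 0.43 log units lower from compound 1 to compound 4 (beyond the scatter), so all three replacements shown now sit on the same side of compound 1. Difluoromethyl cannot be told apart from the two hydroxy-bearing groups, with a number 0.02 log units lower from compound 2 to compound 4 (within the scatter) and a number 0.14 log units higher from compound 3 to compound 4 (within the scatter), which shows that a group without oxygen reaches the same level. Nothing available here explains this shift.

Still open, from the compounds shown here alone, is how a plain methyl, an amine or a carboxylic acid on this carbon would read in this assay. Going by these compounds, whether any replacement of the chloro could leave the number at the level of compound 1 also remains unknown.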